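The source may report more compounds than this note shows. Statements on the series, on what has been measured and on what is new or still open speak of the compounds shown alone.

Working notes on the series. Compound 1 `COc1ccc(-c2cc(-c3ccccc3)n[nH]2)cc1` gives 10400 nM in a functional assay on NCI-H460 cells (Homo sapiens) for inhibition, read by MTT assay, with a stated time of 48 h; on this read-out higher numbers stand for weaker inhibition of growth and lower numbers for stronger inhibition of growth. Within the data shown here, compound 2 `COc1ccc(-c2cc(-c3ccccc3-c3ccccc3)n[nH]2)cc1` gives 730 nM in this assay, and the step of a 14-fold lower number from compound 1 to compound 2 (1.15 log units; beyond the scatter) is the only measured step in the set. On the numbers shown, compound 2 stands at the lowest value of the two, with compound 1 the only neighbour and at a higher number.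

The next compound, compound 3 `Oc1ccccc1-c1cc(-c2ccccc2-c2ccccc2)n[nH]1`, differs from compound 2 by 2-hydroxyphenyl in place of 4-methoxyphenyl on an aromatic carbon. Among the measured compounds shown here, no measured step bears on this change: the single step of a 14-fold lower number from compound 1 to compound 2 (1.15 log units; beyond the scatter) concerns a different group at a different place, so nothing in the measured numbers shows what exchanging the 4-methoxyphenyl for a 2-hydroxyphenyl does in this assay. The expectation therefore rests only on the starting point, the value of compound 2 at 730 nM, and carries a wide range in either direction. Compound 3 is expected to give 1000 nM in this assay, estimated between 200 nM and 6000 nM. The expected step of a 1.4-fold higher number from compound 2 to compound 3 (0.14 log units; within the scatter) is then an estimate of no change beyond the scatter.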

Compound 3, concentration for 50% growth inhibition: 4600 nM
Beside the measured number, compound 3's estimate is 4.6-fold (0.66 log units) below it; measured number inside the range.
By their numbers in this assay, from the lowest: compound 2; then compound 3; then compound 1.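

Exchanging 4-methoxyphenyl for 2-hydroxyphenyl on the aromatic carbon next to the ring nitrogen gives a 6.3-fold higher number from compound 2 to compound 3 (0.80 log units; beyond the scatter) in this assay, so this position responds to the aryl group it carries, which the earlier step, a 14-fold lower number from compound 1 to compound 2 (1.15 log units; beyond the scatter), could not show because it concerned a different place. The exchange alters more than one feature at once: the entering group has 1 hydrogen-bond donor where the leaving group has 0, has 7 heavy atoms against 8, and carries its oxygen on a different ring position, and this single step cannot separate these differences. No measurement at hand offers an explanation for the step.

On these data alone, a 4-hydroxyphenyl or a 2-methoxyphenyl at this place would help separate the effect of the hydroxyl from that of its ring position, so the contribution of each remains open. Also open, as far as these compounds go, is how this assay would read an amine or a carboxylic acid on this aryl ring, or a longer alkoxy chain in place of the methoxy.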